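This account rests on a few compounds, and the source may have more. Where it says the series, first, only, none or still open, it means among the compounds named here.

Measured in a functional assay on the whole organism (strain Wistar albino) for inhibition, with Rattus norvegicus as the target, read by paw edema, with stated times of 1 h and 4 h, at a dose of 40 mg/kg by the oral route; a higher number here means more inhibition at the dose given (going by the name of the read-out), a lower number less inhibition:
compound 1 `COc1ccc(N2C(=O)CSC2c2sc(-c3ccccc3)nc2C)cc1` — 67.1%
compound 2 `Cc1nc(-c2ccccc2)sc1C1SCC(=O)N1c1ccc(F)c(Cl)c1` — 28.6%

Compound 1 stands highest of the two numbers; its nearest neighbour is compound 2, separated by a number 38.5 percentage points lower from compound 1 to compound 2 (beyond the scatter), a change brought by 3-chloro-4-fluorophenyl in place of 4-methoxyphenyl on an amide-type nitrogen in a ring.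

Compound 3 `COc1ccc(N2C(=O)CSC2c2sc(-c3ccc(Cl)cc3)nc2C)cc1` is not yet measured. Against compound 1 the difference is chloro in place of hydrogen on an aromatic carbon, placed on an aromatic carbon of a six-membered aromatic ring of carbon only, para to a large group; cut one bond further out it reads phenyl to 4-chlorophenyl. Among the measured compounds shown here, no measured step touches this ring: the only step known concerns the aryl group on the ring nitrogen, a different part of the shared core. With nothing bearing on it, no step beyond the scatter is expected in this assay in either direction. Compound 3 is therefore expected to give 62%, within 45% to 78%. Compound 3 is thus expected to show a number 5.1 percentage points lower from compound 1 to compound 3 (within the scatter).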

Compound 3, a percentage reported as inhibition, in the whole organism at one dose (the size of the read-out at that dose, not a potency): 59.1%
For compound 3 the middle estimate is 2.9 percentage points above the measured one, and the stated range covers the measured number.
By their numbers in this assay, from the lowest: compound 2; then compounds 3 and 1 (each within the scatter of the next).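

Among the compounds shown here, the change from phenyl to 4-chlorophenyl reaches a part of the shared core that the earlier compounds left untouched, and in this assay it gives a number 8 percentage points lower from compound 1 to compound 3 (within the scatter) and no step beyond the scatter. For the compounds shown here, this site therefore accepts chloro in place of hydrogen while the 4-methoxyphenyl group stays on the ring nitrogen, whereas the only change at that nitrogen gives a number 38.5 percentage points lower from compound 1 to compound 2 (beyond the scatter) and lies beyond the scatter. No measured evidence bears on either outcome.

As far as these compounds go, it remains open whether the same holds at this site for groups other than chloro, such as a methoxy group, an amine or a carboxylic acid. Going by these compounds alone, also open is how 4-chlorophenyl behaves with 3-chloro-4-fluorophenyl on the ring nitrogen, and single-dose numbers give no potency for any compound.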